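Methoxy for methyl on a nitro-bearing bis-benzylidene cyclohexanone

The source may hold more compounds than are shown below. What is called first, only, known or untested is meant among the compounds shown, and "the series" means these compounds.

The study measures cytotoxicity in a functional assay on L1210 cells (Mus musculus) for cytotoxicity, with a stated time of 48 h; on this read-out lower numbers stand for stronger inhibition and higher numbers for weaker inhibition. Of the compounds shown here, three have a number so far. Compound 1 `Cc1ccc(/C=C2\CCC/C(=C\c3cccc([N+](=O)[O-])c3)C2=O)cc1` gives 41800 nM in this assay, which is the lowest of the three numbers; its nearest neighbour, compound 2 `O=C1CCCC/C1=C\c1ccc([N+](=O)[O-])cc1`, gives 46500 nM, a gap that lies within the usual scatter, so no order between compound 1 and compound 2 can be read from it. Compound 3 `CN(C)c1ccc(/C=C2\CCC/C(=C\c3ccccc3[N+](=O)[O-])C2=O)cc1` gives 164000 nM, and this gap to compound 1 lies beyond the scatter. Within the data shown here, none of the three pairs differs in a single place, so no single-point step between measured compounds is available.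

The compound not yet measured, compound 4 `COc1ccc(/C=C2\CCC/C(=C\c3cccc([N+](=O)[O-])c3)C2=O)cc1`, differs from compound 1 in one place: methoxy in place of methyl on an aromatic carbon. The change sits on an aromatic carbon of a six-membered aromatic ring of carbon only, para to a large group, and read one bond further out it is 4-methylphenyl to 4-methoxyphenyl.

Among the measured compounds shown here, nothing among the measured compounds isolates this change, so the expectation rests on the narrow spread of the measured numbers. The step from compound 1 to compound 4 is expected to be a 1.0-fold higher number from compound 1 to compound 4 (0.00 log units; within the scatter), which is none beyond the scatter. Compound 4 is therefore estimated at 42000 nM in this assay, in a range from 15000 nM to 120000 nM.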

Compound 4, half-maximal inhibitory concentration: 29500 nM
Compound 4: middle estimate off by 1.4-fold (0.15 log units), on the high side; low and high end bracket the measured number.
By their numbers in this assay, from the lowest: compounds 4, 1 and 2 (each within the scatter of the next); then compound 3.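

In this assay, among these compounds, the one exchange of methoxy for methyl on an aromatic carbon reads a 1.4-fold lower number from compound 1 to compound 4 (0.15 log units; within the scatter) and so gives no order between the 4-methylphenyl and 4-methoxyphenyl forms. This is the only step among the compounds shown that isolates a single place, which the three earlier compounds could not do, and it shows that at this place, para to a large group, the extra heavy atom and the hydrogen-bond acceptor that methoxy brings leave the number within the scatter of compound 1. No measurement among the data bears on this result, so nothing can be said about what lies behind it.

The compounds shown leave open whether a hydroxyl, an ethoxy, a longer chain or a carboxylic acid at this same aromatic carbon would also stay within the scatter of compound 1 or would move the number beyond it. They also leave open whether methoxy in place of methyl would read the same on a core other than that of compound 1, since this single step is all there is to go on.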